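This account rests on a few compounds, and the source may have more. Where it says the series, first, only, none or still open, it means among the compounds named here.

Compound 1 `Cc1ccn2c(NC3CCCC3)c(-c3ccc(N(C)C)cc3)nc2c1` gives > 1000 uL/min in an ADME assay on microsomes from liver (Mus musculus) for metabolic stability, read by LC-MS, using NADPH, with a stated time of 60 min, tested at 1 uM, in the presence of a further agent that is not named here; on this read-out higher numbers stand for fast clearance and lower numbers for slow clearance; this is a limit of the assay, not a number.
Compound 2 `COc1ccnc(-c2nc3ccccn3c2Nc2ccc(F)cc2)c1` gives > 1000 uL/min in this assay, again a limit rather than a number.
Compound 3 `N#Cc1ccn2c(Nc3ccc(F)cc3)c(-c3ccccn3)nc2c1` gives 146 uL/min in this assay.

Compound 3 is therefore the only one of the three with a real number, while the other two sit at the limit of > 1000 uL/min in this assay, at which 2 of the 3 values shown sit. Among the compounds with values here, no two measured compounds differ in just one place, so no measured step exists to lean on. Compound 4 `Cc1ccn2c(Nc3ccc(F)cc3)c(-c3ccccn3)nc2c1` differs from compound 3 in one place: methyl in place of cyano on an aromatic carbon. With methyl in place of cyano, compound 4 is expected to clear faster than compound 3, the expected step being a 3.1-fold higher number from compound 3 to compound 4 (0.49 log units; beyond the scatter). Compound 4 is thus estimated at 450 uL/min, within a range from 150 uL/min to 1300 uL/min.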

Compound 4, intrinsic clearance in a liver preparation (reported as CLH), per the amount of preparation that the assay uses: 354 uL/min
Estimate against measurement, compound 4: 1.3-fold (0.10 log units) above; the measured number falls inside the stated range.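

Methyl in place of cyano on this aromatic carbon gives a 2.4-fold higher number from compound 3 to compound 4 (0.38 log units; beyond the scatter) in this assay and this is the first measured step in the series. It shows that a change at this one place on the shared core moves clearance by more than the usual scatter, even though neither compound has a group on this carbon that is large. Compound 4 still gives a real number and does not reach the limit: the limit of > 1000 uL/min in this assay, at which 2 of the 4 values shown sit.

A single step cannot show why the number moves. Going by these compounds, what an amine or a carboxylic acid at this place would do remains open.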